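A few compounds are considered here, and "the series" means these few. Any claim that something is new, unique, unknown or untested is made for them only; others in the source may bear on it.

Two compounds share one core and differ only in the group on the outer aromatic ring. Compound 1 `Cc1ccccc1-c1cccc(COc2ccc([C@H](CC(=O)O)c3nccn3C)cc2)c1` carries a methyl there and gives 89000 nM in an assay on CHO cells for agonist activity at Free fatty acid receptor 1 (Homo sapiens), read by luminescence, with a stated time of 20 s, in the presence of a further agent that is not named here; on this read-out higher numbers stand for an effect only at larger amounts of compound and lower numbers for an effect already at smaller amounts. Among the measured compounds shown here, compound 2 `CCc1ccccc1-c1cccc(COc2ccc([C@H](CC(=O)O)c3nccn3C)cc2)c1` carries an ethyl and gives 65000 nM in this assay; this is the lowest of the two numbers, and the only measured step, a 1.4-fold lower number from compound 1 to compound 2 (0.14 log units; within the scatter), lies within the scatter. Compound 3 `Cn1ccnc1[C@@H](CC(=O)O)c1ccc(OCc2cccc(-c3ccccc3Cl)c2)cc1` differs from compound 2 in one place: chloro in place of ethyl on an aromatic carbon. For the measured compounds named here, no measured step exchanges ethyl for chloro, so the sole guide is that the step from compound 1 to compound 2 at the same spot hardly moved the number, and the change from compound 2 to compound 3 is expected to do likewise, namely no change at the digits printed from compound 2 to compound 3 (within the scatter). Compound 3 is therefore estimated at 65000 nM, within a range from 25000 nM to 170000 nM.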

Compound 3, half-maximal effective concentration: 56000 nM
The estimate for compound 3 lay 1.2-fold (0.06 log units) above the measured number, within the range that was stated.
By their numbers in this assay, from the lowest: compounds 3, 2 and 1 (each within the scatter of the next).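

In this assay, chloro in place of ethyl gives a 1.2-fold lower number from compound 2 to compound 3 (0.06 log units; within the scatter), and chloro in place of methyl gives a 1.6-fold lower number from compound 1 to compound 3 (0.20 log units; within the scatter). The earlier pair held only carbon groups at this position, whereas these steps add a group with a chlorine atom, and none of the three groups separates from the others beyond the scatter. Nothing shown here explains why these exchanges leave the number within the scatter.

Going by these compounds, it remains open whether a longer chain such as propyl, an oxygen-linked group such as methoxy, an amine or a carboxylic acid at this position would shift the number beyond the scatter. Also open, on these data alone, is whether chloro would give the same result on another carbon of this ring.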